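The compounds below may be only part of what the source reports. "The series", "measured", "known", "first", "only" and "open" are said of these compounds alone.

Measured so far:
compound 1, `ClCc1ccc(Cn2cnc3c(Cl)ncnc32)cc1`: 7940 nM
compound 2, `ClCc1cccc(Cn2cnc3c(Cl)nc(Cl)nc32)c1`: 2340 nM

Of the compounds shown here, two have been tested in a functional assay on SK-MEL-28 cells (Homo sapiens) for cytotoxicity, read by sulforhodamine B assay, with a stated time of 48 h; a higher number here means a weaker inhibitor of growth, a lower number a stronger inhibitor of growth. Compound 1 has the higher of the two numbers; in this assay compound 1 gives 7940 nM, while compound 2 gives 2340 nM, a gap that lies beyond the usual scatter. Going by the values given here, no pair of measured compounds differs in a single place, so no measured step is available to guide a reading of substituent effects.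

Compound 3, `Nc1nc(Cl)c2ncn(Cc3ccc(CCl)cc3)c2n1`, is the next compound to be measured. It differs from compound 1 by amino in place of hydrogen on an aromatic carbon.

Since nothing in the measured pair shows what an amino group at this carbon does, the size and direction of the step in this assay cannot be derived from the data; a step within the scatter, or a modest lowering, both appear plausible. Compound 3 is expected to give about 5000 nM in this assay, within a range of 1500 nM to 16000 nM, which would mean an estimated step of a 1.6-fold lower number from compound 1 to compound 3 (0.20 log units; within the scatter).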

Compound 3, concentration for 50% growth inhibition: 18200 nM
Beside the measured number, compound 3's estimate is 3.6-fold (0.56 log units) below it; the whole stated range lies below it.
By their numbers in this assay, from the lowest: compound 2; then compound 1; then compound 3.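

In this assay, the series now has its first single-place step: amino in place of hydrogen on an aromatic carbon, between two ring nitrogen atoms, gives a 2.3-fold higher number from compound 1 to compound 3 (0.36 log units; beyond the scatter) and so points towards weaker growth inhibition. This shows that growth inhibition responds to a change at this carbon, and that adding amino here, with the rest of compound 1 unchanged, does not strengthen it. The step is modest and rests on a single pair, and no measurement at hand accounts for its direction.

On these data alone, whether the step follows from amino itself or would be shared by other groups on this carbon remains open, and a methylamino group, a methoxy group or a hydroxyl group there would help to separate these readings. As far as these compounds go, it is also open whether amino would give a step of the same direction and size in a compound that differs elsewhere from compound 1, so no general rule for this position can yet be drawn.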